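The source may hold more compounds than are shown below. What is called first, only, known or untested is meant among the compounds shown, and "the series" means these compounds.

Compound 2 `Cn1c(=O)c(S(=O)(=O)Nc2ccc(F)cc2F)cc2cnc(Nc3ccc4[nH]ccc4c3)nc21` gives 5000 nM in a functional assay on DU-145 cells (Homo sapiens) for inhibition, read by trypan blue exclusion, with a stated time of 72 h (on this read-out higher numbers stand for weaker inhibition and lower numbers for stronger inhibition), the higher of the two numbers recorded there. Compound 1 `Cn1c(=O)c(S(=O)(=O)c2ccc(Cl)cc2)cc2cnc(Nc3ccc4[nH]ccc4c3)nc21` gives 250 nM in this assay. Among the compounds with values here, the single measured step, a 20-fold higher number from compound 1 to compound 2 (1.30 log units; beyond the scatter), replaced the group on the sulfonyl sulfur. Compound 3 `Cn1c(=O)c(S(=O)(=O)c2ccc(Br)cc2)cc2cnc(Nc3ccc4[nH]ccc4c3)nc21` differs from compound 2 in 4-bromophenyl in place of (2,4-difluorophenyl)amino on a sulfonyl sulfur. This change largely reverses the measured step, so the step of a 17-fold lower number from compound 2 to compound 3 (1.22 log units; beyond the scatter) is expected to run toward stronger inhibition, roughly matching that earlier step in size. Compound 3 is therefore estimated at 300 nM, within a range from 100 nM to 1000 nM.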

Compound 3, half-maximal inhibitory concentration: 5000 nM
Estimate against measurement, compound 3: 17-fold (1.22 log units) below; measured number outside the range, above it.
By their numbers in this assay, from the lowest: compound 1; then compounds 2 and 3 (each within the scatter of the next).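

Replacing chloro with bromo on an aromatic carbon gives a 20-fold higher number from compound 1 to compound 3 (1.30 log units; beyond the scatter) in this assay, so even this one-atom change on the group held by the sulfonyl sulfur can matter greatly. Exchanging (2,4-difluorophenyl)amino for 4-bromophenyl gives no change at the digits printed from compound 2 to compound 3 (within the scatter), so a halogen-bearing phenyl directly on the sulfur does not by itself restore the lower number seen with 4-chlorophenyl. Nothing available explains the gap between the chloro and bromo compounds. From the compounds shown here alone, what a plain phenyl or a 4-fluorophenyl would give on this sulfur remains open. So does the effect of a 4-methoxyphenyl, which carries no halogen.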